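Ring-Closed Amide: Expectation for Compound 4

This account rests on a few compounds, and the source may have more. Where it says the series, first, only, none or still open, it means among the compounds named here.

Compound 1 `CNC(=O)CC1CCc2cc(OC)c(OC)cc21` is the smallest of three measured compounds sharing one core and one amide-bearing side chain. In a functional assay on the whole organism (strain Wistar) for inhibition, with Rattus norvegicus as the target, read by paw edema, with stated times of 60 min and 24 h, at a dose of 100 mg/kg by the oral route (on this read-out higher numbers stand for more inhibition at the one dose given (going by the name of the read-out) and lower numbers for less inhibition), compound 1 gives 33.3%, the lowest of the three numbers. Compound 2 `CCCCCNC(=O)CC1CCc2cc(OC)c(OC)cc21` gives 46.7%, and compound 3 `COc1cc2c(cc1OC)C(CC(=O)NCc1ccccc1)CC2` gives 43.3%. The step of a number 13.4 percentage points higher from compound 1 to compound 2 (beyond the scatter) lies beyond the scatter, while the step of a number 10 percentage points higher from compound 1 to compound 3 (within the scatter) does not, and between compound 2 and compound 3 the step of a number 3.4 percentage points lower from compound 2 to compound 3 (within the scatter) is also within the scatter.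

Compound 4 `COc1cc2c(cc1OC)C(CC(=O)N1CCCC1)CC2` is not yet measured. It differs from compound 1 in one place: pyrrolidin-1-yl in place of methylamino on a carbonyl carbon. The amide hydrogen is lost and the nitrogen becomes part of a five-membered ring. Within the data shown here, no measured step removes the amide hydrogen, so the bearing of the two measured steps is indirect: both enlarge the group on the saturated chain carbon bound to an amide-type nitrogen, and both moved the number upward, modestly for compound 2 and within the scatter for compound 3. Enlarging what sits on the nitrogen of compound 1 therefore seems likelier to raise than to lower the number, though only by a small to modest amount.

Compound 4 is therefore expected to give 42%, within a range of 28% to 56%, corresponding to an expected step of a number 8.7 percentage points higher from compound 1 to compound 4 (within the scatter).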

Compound 4, a percentage reported as inhibition, in the whole organism at one dose (the size of the read-out at that dose, not a potency): 33.3%
For compound 4 the middle estimate is 8.7 percentage points above the measured one, within the range that was stated.
By their numbers in this assay, from the lowest: compounds 1, 4, 3 and 2 (each within the scatter of the next, the first and the last beyond it).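

In this assay, replacing methylamino on the carbonyl carbon with pyrrolidin-1-yl gives no change at the digits printed from compound 1 to compound 4 (within the scatter), so a larger group at this position does not by itself shift the number, even though the earlier enlargement to pentylamino did. The open chain and the ring can also be set side by side at this position: pentylamino to pyrrolidin-1-yl gives a number 13.4 percentage points lower from compound 2 to compound 4 (beyond the scatter), a modest step beyond the scatter, whereas benzylamino to pyrrolidin-1-yl gives a number 10 percentage points lower from compound 3 to compound 4 (within the scatter), which stays within it. Nothing available here explains why pentylamino and pyrrolidin-1-yl differ.

The change from methylamino to pyrrolidin-1-yl removes the amide hydrogen and adds a ring at once, so the compounds shown cannot say which of the two goes with the gap from compound 2; a dimethylamino group would lose that hydrogen without forming a ring, while a cyclopentylamino group would keep it and carry a ring. A six-membered piperidin-1-yl ring in the same place would show whether ring size matters at this carbonyl carbon.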